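Hydroxyphenyl to pyrazolylmethyl at the amide carbonyl

The source may report more compounds than this note shows. Statements on the series, on what has been measured and on what is new or still open speak of the compounds shown alone.

Measured so far in an assay on cells for positive allosteric modulation of Cystic fibrosis transmembrane conductance regulator variant F508del (Homo sapiens), with stated times of 10 min and 7 s, in the presence of a further agent that is not named here; a higher number here means that more compound is needed for the effect, a lower number that less compound is needed:
- compound 1 `CC1(C)Cc2c(sc(NC(=O)c3ccccc3O)c2C(N)=O)CO1`: 13 nM
- compound 2 `CC1Cc2c(sc(NC(=O)c3ccccc3O)c2C(N)=O)C(C)O1`: 4 nM
- compound 3 `CC1(C)Cc2c(sc(NC(=O)c3ccccc3O)c2C(N)=O)C(C)(C)O1`: 4 nM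

Compound 3 stands level with compound 2 at the digits shown; these two together give the lowest numbers of the three. Compound 1 sits higher than compound 3, and that gap lies beyond the usual scatter.

Compound 4 `CC1(C)Cc2c(sc(NC(=O)Cc3ccn[nH]3)c2C(N)=O)C(C)(C)O1` differs from compound 3 in one place: (1H-pyrazol-5-yl)methyl in place of 2-hydroxyphenyl on a carbonyl carbon. For the measured compounds named here, no measured pair shows this kind of change, so the size of the step is open. The expectation is a loss, a step of more than the scatter in the direction of a higher number, as the change removes the aromatic hydroxyphenyl group shared by all three measured compounds.

For compound 4 the estimate in this assay is 40 nM, with a range from 8 nM to 300 nM.

This estimate corresponds to an expected step of a 10-fold higher number from compound 3 to compound 4 (1.00 log units; beyond the scatter).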

Compound 4, half-maximal effective concentration: 136 nM
For compound 4 the middle estimate is 3.4-fold (0.53 log units) below the measured one; measured number inside the range.
By their numbers in this assay, from the lowest: compounds 2 and 3 (each within the scatter of the next); then compound 1; then compound 4.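

In this assay, (1H-pyrazol-5-yl)methyl in place of 2-hydroxyphenyl on the carbonyl carbon gives a 34-fold higher number from compound 3 to compound 4 (1.53 log units; beyond the scatter) as the first step read at this place, which shows that the number responds strongly to a change here. The two groups have the same counts of hydrogen-bond donors and acceptors, so matching those counts does not preserve the low number. Nothing available accounts for the rise.

Going by these compounds, the step changes the ring and adds a carbon link together, so the contribution of each remains open. A 2-hydroxybenzyl group or a pyrazolyl ring bound directly to the carbonyl would separate the two.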